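The compounds below may be only part of what the source reports. "The series", "measured", "known", "first", "only" and "open" are said of these compounds alone.

Measured so far in a functional assay on LoVo cells (Homo sapiens) for inhibition, read by MTT assay, with a stated time of 72 h; a higher number here means a weaker inhibitor, a lower number a stronger inhibitor:

compound 1, `Cc1noc(C)c1-c1cnc(N)c(Oc2ccc(C(=O)Nc3cccc(Cl)c3)cc2)n1`: 1640 nM
compound 2, `Cc1noc(C)c1-c1cnc(N)c(Oc2ccc(C(=O)Nc3cccc(Cl)n3)cc2)n1`: 39300 nM

Going by the values given here, compound 1 is the stronger of the two measured inhibitors, with the lower of the two numbers; its only neighbour is compound 2, and the step of a 24-fold higher number from compound 1 to compound 2 (1.38 log units; beyond the scatter) lies well outside the scatter. Compound 3, `Cn1cc(-c2cnc(N)c(Oc3ccc(C(=O)Nc4cccc(Cl)c4)cc3)n2)cn1`, has not yet been measured. It keeps the shared core of compound 1 and its amide part unchanged, and differs only at the five-membered ring: 1-methyl-1H-pyrazol-4-yl in place of 3,5-dimethyl-1,2-oxazol-4-yl on an aromatic carbon. Among the compounds with values here, the one measured step, from compound 1 to compound 2, alters a different part of the molecule and therefore says nothing directly about an exchange of the five-membered ring; no measured pair here probes that position. With no evidence for this change, the expectation for compound 3 in this assay is a number close to that of compound 1, a step of a 1.2-fold higher number from compound 1 to compound 3 (0.09 log units; within the scatter) that is not expected to exceed the scatter. The estimate for compound 3 is 2000 nM, with a range from 600 nM to 7000 nM.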

Compound 3, half-maximal inhibitory concentration: 24500 nM
Beside the measured number, compound 3's estimate is 12-fold (1.09 log units) below it; the measured number lies above the stated range.
By their numbers in this assay, from the lowest: compound 1; then compounds 3 and 2 (each within the scatter of the next).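

In this assay, the group on this aromatic carbon of the shared core proves to matter: putting 1-methyl-1H-pyrazol-4-yl in place of 3,5-dimethyl-1,2-oxazol-4-yl gives a 15-fold higher number from compound 1 to compound 3 (1.17 log units; beyond the scatter). Until now, only the amide end of the molecule had been shown to respond to a change, and this step shows that the five-membered ring at the other end responds as well, even though the entering and leaving groups have the same counts of hydrogen-bond donors and acceptors, the same lack of net charge, and each has one five-membered aromatic ring with 2 hetero atoms. Nothing available explains why this exchange weakens inhibition so much.

The exchange changes the ring atoms and the methyl groups at once, so the compounds shown leave open which of these differences matters, a question that 3,5-dimethyl-1H-pyrazol-4-yl at the same position could help to separate. They also leave open how a group of another kind, such as a simple amine or a carboxylic acid, would fare there.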